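Amino in Place of Methoxy on the Aryl Ring

A few compounds are considered here, and "the series" means these few. Any claim that something is new, unique, unknown or untested is made for them only; others in the source may bear on it.

The study records two compounds with numbers. Compound 1 `COC(=O)C1=C(C)N=C(C)/C(=C(\O)OC)C1c1cccc(OC)c1` gives 191 nM in a functional assay (muscle tissue) with Cavia porcellus as the target (a lower number here means that less compound is needed, a higher number that more compound is needed for the effect), the highest of the two values; compound 2 `COC(=O)C1=C(C)NC(C)=C(C(=O)OC)C1c1ccccc1` gives 28.2 nM in this assay, but the two differ in more than one place, so only the gap itself is known. Compound 3 `COC(=O)C1=C(C)N=C(C)/C(=C(\O)OC)C1c1cccc(N)c1` is unmeasured; it differs from compound 1 by amino in place of methoxy on an aromatic carbon. Within the data shown here, no single-change step is available to guide the size of the effect. Compound 3 is expected to need somewhat more compound, a step of a 2.1-fold higher number from compound 1 to compound 3 (0.32 log units; beyond the scatter), estimated at 400 nM with a range from 120 nM to 1500 nM.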

Compound 3, half-maximal effective concentration: 2000 nM
The estimate for compound 3 lay 5.0-fold (0.70 log units) below the measured number, and the stated range ends below it.
By their numbers in this assay, from the lowest: compound 2; then compound 1; then compound 3.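

In this assay, among these compounds, the change from 3-methoxyphenyl to 3-aminophenyl gives a 10-fold higher number from compound 1 to compound 3 (1.02 log units; beyond the scatter), the only single-change step available. It shows that the number at this place on the shared core depends strongly on which group is attached, and that this exchange moves it upward. Nothing at hand explains the size of this step.

The compounds shown leave open how a hydroxyl, methylamino or acetamido group would read at this place. They also leave open whether the same exchange would give a similar step on another core.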